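Trifluoromethyl for (trifluoromethyl)sulfanyl in a urea series

The source may hold more compounds than are shown below. What is called first, only, known or untested is meant among the compounds shown, and "the series" means these compounds.

Compound 1 `Cc1cc(NC(=O)Nc2ccc(N)cc2)c2ccccc2n1` is reported in an ADME assay on HepG2 cells (Homo sapiens) for cytotoxicity, with a stated time of 72 h (a lower number here means that less compound is needed, a higher number that more compound is needed for the effect), only as a limit, > 25000 nM.
Compound 2 `CC(=O)c1ccc(NC(=O)Nc2cc(C)nc3ccccc23)cc1` gives in this assay 19000 nM.
Compound 3 `Cc1cc(NC(=O)Nc2ccc(SC(F)(F)F)cc2)c2ccccc2n1` gives in this assay 20000 nM.

Among the numbers measured, compound 3 and compound 2 lie within the scatter of each other, a 1.1-fold higher number from compound 2 to compound 3 (0.02 log units; within the scatter), while compound 1 sits at the limit (the limit of > 25000 nM in this assay, at which 1 of the 3 values shown sits). Compound 4 `Cc1cc(NC(=O)Nc2ccc(C(F)(F)F)cc2)c2ccccc2n1` differs from compound 3 in one place: trifluoromethyl in place of (trifluoromethyl)sulfanyl on an aromatic carbon. Within the data shown here, no measured step exchanges these two groups; the steps from compound 1 and compound 2 to compound 3, an at least 1.2-fold lower number from compound 1 to compound 3 (0.09 log units; that floor lies within the scatter) and a 1.1-fold higher number from compound 2 to compound 3 (0.02 log units; within the scatter), swap other groups at the same place and stay within the scatter. Compound 4 is therefore expected to move no further than the scatter, no change at the digits printed from compound 3 to compound 4 (within the scatter), and its estimated value in this assay is 20000 nM, between 10000 nM and 40000 nM.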

Compound 4, half-maximal effective concentration: 23000 nM
The estimate for compound 4 lay 1.2-fold (0.06 log units) below the measured number; the range from low to high includes it.
By their numbers in this assay, from the lowest: compounds 2, 3 and 4 (each within the scatter of the next). At a limit, above all of these: compound 1.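

In this assay, the direct exchange of (trifluoromethyl)sulfanyl for trifluoromethyl on this aromatic carbon, para to a large group, gives a 1.2-fold higher number from compound 3 to compound 4 (0.06 log units; within the scatter). Trifluoromethyl in place of acetyl at the same place gives a 1.2-fold higher number from compound 2 to compound 4 (0.08 log units; within the scatter), so neither exchange moves the number beyond the scatter. Trifluoromethyl in place of amino can be read only as a floor, an at least 1.0-fold lower number from compound 1 to compound 4 (0.03 log units; that floor lies within the scatter), and the value of compound 1 is a limit: the limit of > 25000 nM in this assay, at which 1 of the 4 values shown sits.

From the compounds shown here alone, whether a carboxylic acid or a longer chain at this place would move the number beyond the scatter stays open. So does the actual value of compound 1.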